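The source may report more compounds than this note shows. Statements on the series, on what has been measured and on what is new or still open speak of the compounds shown alone.

Measured so far in a functional assay on EC9706 cells (Homo sapiens) for cytotoxicity, read by MTT assay, with a stated time of 72 h; on this read-out lower numbers stand for stronger inhibition and higher numbers for weaker inhibition:
compound 1, `O=C(CSC(=S)N[C@H]1CCOC1=O)Nc1ccccc1F`, gives > 128000 nM, a limit of the assay.
compound 2, `O=C(CSC(=S)N[C@H]1CCOC1=O)Nc1ccccc1Cl`, gives > 128000 nM, likewise a limit.

Compound 2 therefore stands only at a limit, with no number attached. The step that the two limits leave unreadable from compound 1 to compound 2 stays unreadable since the limit of > 128000 nM in this assay, at which 2 of the 2 values shown sit, covers both values. Compound 3, `Cc1ccc(NC(=O)CSC(=S)N[C@H]2CCOC2=O)cc1`, differs by 4-methylphenyl in place of 2-chlorophenyl on an amide-type nitrogen. Within the data shown here, no measured step with a readable size bears on this change, and the one comparison at hand, a step that the two limits leave unreadable from compound 1 to compound 2, gives no direction. No step beyond the scatter is expected in this assay, and compound 3 will most probably again return a limit. Compound 3 is estimated at 150000 nM, range 50000 nM to 450000 nM, which as an expected step means a step that the limit leaves unreadable from compound 2 to compound 3.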

Compound 3, half-maximal inhibitory concentration: 93900 nM
Compound 3: middle estimate off by 1.6-fold (0.20 log units), on the high side; low and high end bracket the measured number.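

In this assay, among these compounds, compound 3 gives 93900 nM, the only value shown that is not a limit. On the amide-type nitrogen, 4-methylphenyl in place of 2-chlorophenyl gives an at least 1.3-fold lower number from compound 2 to compound 3 (0.13 log units; that floor lies within the scatter), and 4-methylphenyl in place of 2-fluorophenyl gives an at least 1.3-fold lower number from compound 1 to compound 3 (0.13 log units; that floor lies within the scatter). The true size of these steps stays unknown, and the step between compound 1 and compound 2 still cannot be read, because: the limit of > 128000 nM in this assay, at which 2 of the 3 values shown sit.

As far as these compounds go, whether the methyl group itself or its place on the ring matters remains open. Also open, from the compounds shown here alone, is how an amine or a carboxylic acid on that ring would read here.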